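The compounds below may be only part of what the source reports. "The series", "measured", "known", "first", "only" and "open" are said of these compounds alone.

Among the compounds with values here, in a functional assay on HepG2 cells (Homo sapiens) for inhibition, read by MTT assay, with a stated time of 48 h (on this read-out lower numbers stand for stronger inhibition and higher numbers for weaker inhibition), three compounds with a shared core have numbers so far. Compound 1 `COc1ccc(/C=C2\SC(=O)N(CC(=O)Nc3c(C)n(C)n(-c4ccccc4)c3=O)C2=O)cc1` gives 68500 nM, compound 2 `Cc1c(NC(=O)CN2C(=O)S/C(=C\c3ccc([N+](=O)[O-])cc3)C2=O)c(=O)n(-c2ccccc2)n1C` gives 84300 nM, and compound 3 `Cc1c(NC(=O)CN2C(=O)S/C(=C\c3ccc(Cl)cc3)C2=O)c(=O)n(-c2ccccc2)n1C` gives 31900 nM, the lowest of the three. Compound 4 `Cc1cc(C)c(/C=C2\SC(=O)N(CC(=O)Nc3c(C)n(C)n(-c4ccccc4)c3=O)C2=O)c(C)c1` differs from compound 3 as follows: 2,4,6-trimethylphenyl in place of 4-chlorophenyl on a double-bonded chain carbon bound to a double-bonded ring carbon. Within the data shown here, no measured step covers this replacement. The closest evidence is the exchange of single groups on an aromatic carbon, which gave modest steps in a 2.1-fold lower number from compound 1 to compound 3 (0.33 log units; beyond the scatter) and a 2.6-fold lower number from compound 2 to compound 3 (0.42 log units; beyond the scatter), while a 1.2-fold higher number from compound 1 to compound 2 (0.09 log units; within the scatter) stayed within the scatter. A modest rise in this assay is therefore expected, with the estimated change being a 1.6-fold higher number from compound 3 to compound 4 (0.20 log units; within the scatter). Compound 4 is expected at 50000 nM, within an estimated range of 22000 nM to 110000 nM.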

Compound 4, half-maximal inhibitory concentration: 63500 nM
Compound 4: the middle estimate sits 1.3-fold (0.10 log units) below what was measured; measured number inside the range.
By their numbers in this assay, from the lowest: compounds 3, 4, 1 and 2 (each within the scatter of the next, the first and the last beyond it).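

In this assay the 2,4,6-trimethylphenyl group, the only one here carrying more than one substituent on its ring, gives a 2.0-fold higher number from compound 3 to compound 4 (0.30 log units; within the scatter) when set against 4-chlorophenyl. Against 4-nitrophenyl and 4-methoxyphenyl it gives a 1.3-fold lower number from compound 2 to compound 4 (0.12 log units; within the scatter) and a 1.1-fold lower number from compound 1 to compound 4 (0.03 log units; within the scatter) and so stands level with both, which shows that this position takes three methyl groups with no step beyond the scatter. Nothing measured here gives a cause for these steps. The compounds shown leave open whether a single methyl group, an amine or a carboxylic acid on this ring would give a number beyond the scatter of these four.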